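The compounds below may be only part of what the source reports. "The series", "measured", "known", "first", "only" and "open" are said of these compounds alone.

Two compounds that differ only in the group on a sulfur have been measured in a functional assay on SMMC-7721 cells (Homo sapiens) for inhibition, read by CCK-8 assay, with a stated time of 72 h, tested at 8 uM; a higher number here means more inhibition of growth at the concentration tested, a lower number less inhibition of growth. In it, compound 1 `COc1ccc(SCc2ccc(/C=C/C(=O)Nc3ccccc3N)cc2)cc1OC`, which carries 3,4-dimethoxyphenyl, gives 44.6%. Going by the values given here, compound 2 `CCc1ccc(SCc2ccc(/C=C/C(=O)Nc3ccccc3N)cc2)cc1`, which carries 4-ethylphenyl, gives 19.5%, the lower of the two numbers and well beyond the scatter from its only neighbour. Compound 3 `Nc1ccccc1NC(=O)/C=C/c1ccc(CSc2ccc(C(F)(F)F)cn2)cc1` keeps the shared core and changes the group at that same place, with 5-(trifluoromethyl)pyridin-2-yl in place of 4-ethylphenyl on a sulfur. Among the compounds with values here, one measured step bears on this change: a number 25.1 percentage points lower from compound 1 to compound 2 (beyond the scatter). That modest step, made on the same sulfur, shows that the group there can move the number in this assay. However, it does not involve the group that enters now, so it gives no firm direction. A step of similar or smaller size is therefore expected, leaning slightly upward, as compound 2 stands at 19.5%, the bottom of the small measured range. The expected change is a number 8.5 percentage points higher from compound 2 to compound 3 (within the scatter), which may not clear the scatter. For compound 3, the estimated value is 28%, with an expected range from 9% to 50%.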

Compound 3, percent growth inhibition at one concentration: 20.1%
Estimate against measurement, compound 3: 7.9 percentage points above; the measured number falls inside the stated range.
By their numbers in this assay, from the lowest: compounds 2 and 3 (each within the scatter of the next); then compound 1.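

In this assay, 5-(trifluoromethyl)pyridin-2-yl in place of 4-ethylphenyl on the sulfur gives a number 0.6 percentage points higher from compound 2 to compound 3 (within the scatter), so these two groups cannot be told apart here, even though they differ in heavy atoms, in ring composition and in hydrogen-bond acceptors. The step of a number 24.5 percentage points lower from compound 1 to compound 3 (beyond the scatter) shows that 3,4-dimethoxyphenyl now stands apart from two different groups rather than one, alongside the earlier a number 25.1 percentage points lower from compound 1 to compound 2 (beyond the scatter), and compound 1 is the only one of the three that is separated from the others beyond the scatter. Nothing available here accounts for why compound 1 stands apart or why compound 2 and compound 3 do not differ.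

The compounds shown leave open whether both methoxy groups of 3,4-dimethoxyphenyl are required for the higher number, a question that a 4-methoxyphenyl or an unsubstituted phenyl on the sulfur would address. They also leave open whether a ring bearing an amine or a carboxylic acid would stay level with compound 2 and compound 3 or rise toward compound 1.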